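The source may hold more compounds than are shown below. What is called first, only, known or untested is meant among the compounds shown, and "the series" means these compounds.

Measured so far:
Compound 1 `Cc1c[nH]c2c(NC(N[C@H]3CCCCN(CC(=O)N4CCCC4)C3=O)=C(C#N)C#N)cccc12`: 77%
Compound 2 `Cc1c[nH]c2c(N/C(N[C@H]3CCCCN(CC(=O)N4CCCC4)C3=O)=C(/C#N)C(=O)N(C)C)cccc12`: 80%

The two compounds were tested in an ADME assay on a cell-free system (serum, Homo sapiens) for protein binding, using equilibrium dialysis, with a stated time of 4 h, tested at 10 uM. Compound 2 gives 80% in this assay and compound 1 gives 77% in the same test, so the two values lie within the scatter of each other and neither can be placed ahead of the other.

The next compound is compound 3 `CN(C)C(=O)/C(C#N)=C(\Nc1cccc2c(Cl)c[nH]c12)N[C@H]1CCCCN(CC(=O)N2CCCC2)C1=O`, which differs from compound 2 in one place: chloro in place of methyl on an aromatic carbon. This puts chloro in place of methyl on an aromatic carbon, turning 3-methyl-1H-indol-7-yl into 3-chloro-1H-indol-7-yl.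

For the measured compounds named here, no measured pair of compounds here differs in one place only, so the data offer no direct precedent for this exchange. The expectation therefore rests on the swap of a single heavy atom and on the close agreement of the two known values. No step beyond the scatter is expected in this assay, and no direction can be firmly expected. The estimated change is a 1.1-fold lower unbound fraction from compound 2 to compound 3 (0.02 log units; within the scatter) and would stay within the scatter. For compound 3 the estimated value is 81%, with an expected range from 65% to 91%.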

Compound 3, plasma protein binding: 84%
Compound 3: middle estimate off by 1.2-fold (0.07 log units) (unbound fraction), on the high side, within the range that was stated.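

In this assay, chloro in place of methyl on an aromatic carbon, turning 3-methyl-1H-indol-7-yl into 3-chloro-1H-indol-7-yl, gives a 1.3-fold lower unbound fraction from compound 2 to compound 3 (0.10 log units; within the scatter), and this is the only step shown that isolates a single place on the shared core. For the compounds shown here, at this position on the five-membered aromatic ring, two groups of one heavy atom each, neither with a hydrogen-bond donor or acceptor, therefore cannot be told apart in this read-out, which the earlier compounds could not show because neither of them carried a second group at this carbon. Nothing available explains this result or ties it to any property of either group.

The compounds shown leave open whether a group of another kind at this same carbon, such as an amine, a carboxylic acid or a longer alkyl chain, would give a step beyond the scatter. They also leave open whether plain hydrogen at this carbon would read like methyl and chloro, and whether the exchange of methyl for chloro would read the same way elsewhere on the shared core.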